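Extending the Chain from Compound 3 to Compound 4

This account rests on a few compounds, and the source may have more. Where it says the series, first, only, none or still open, it means among the compounds named here.

In a functional assay, read by spectrophotometry, with a stated time of 6 min (on this read-out lower numbers stand for stronger inhibition and higher numbers for weaker inhibition), compound 1 (`CCCCOc1cc(OC)c(Br)cc1C(C)=O`) gives 34100000 nM while compound 2 (`CCCCCCOc1cc(OC)c(Br)cc1C(C)=O`) gives 35700000 nM and compound 3 (`CCCCCCCCOc1cc(OC)c(Br)cc1C(C)=O`) gives 32000000 nM as its value. Compound 3 therefore sits level with the other two, within the scatter of each. Compound 4 (`CCCCCCCCCCCCOc1cc(OC)c(Br)cc1C(C)=O`) differs from it by one change (butyl in place of hydrogen on a saturated chain carbon, eight bonds along the chain from an oxygen on an aromatic ring) that extends the chain further. The closest measured step is a 1.1-fold lower number from compound 1 to compound 3 (0.03 log units; within the scatter) for the same butyl in place of hydrogen, there four bonds along the chain. The two ethyl steps are a 1.0-fold higher number from compound 1 to compound 2 (0.02 log units; within the scatter) and a 1.1-fold lower number from compound 2 to compound 3 (0.05 log units; within the scatter) at four and six bonds along the chain. All three stay within the scatter, so no step beyond it is expected in this assay for this change. Going by the values given here, still, no measured compound carries a change at eight bonds along the chain, so the range is kept wide. The expected move is a 1.1-fold lower number from compound 3 to compound 4 (0.03 log units; within the scatter) on this estimate. Compound 4 is estimated at 30000000 nM with an expected range from 14000000 nM to 55000000 nM around that figure.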

Compound 4, half-maximal inhibitory concentration: 32700000 nM
Compound 4: middle estimate off by 1.1-fold (0.04 log units), on the low side; measured number inside the range.
By their numbers in this assay, from the lowest: compounds 3, 4, 1 and 2 (each within the scatter of the next).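

In this assay, going by these compounds alone, butyl in place of hydrogen on a saturated chain carbon, eight bonds along the chain from an oxygen on an aromatic ring, gives a 1.0-fold higher number from compound 3 to compound 4 (0.01 log units; within the scatter) and so leaves the number level at a position the earlier steps did not reach. Larger changes in the chain read the same way: hexyl at six bonds along the chain gives a 1.1-fold lower number from compound 2 to compound 4 (0.04 log units; within the scatter) and octyl at four bonds along the chain gives a 1.0-fold lower number from compound 1 to compound 4 (0.02 log units; within the scatter) and, like the earlier steps, both stay within the scatter. Across these four compounds, none goes against this level pattern. As far as these compounds go, whether an amine or a carboxylic acid carried on the chain, or a longer chain, would depart from this level remains open. Nothing available explains why the numbers stay level across these chains.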